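Sulfoxide to Sulfone at the Chain Sulfur: Expected Tolerability

The source may report more compounds than this note shows. Statements on the series, on what has been measured and on what is new or still open speak of the compounds shown alone.

Compound 3 `COC(=O)N[C@@H](C[S+]([O-])Cc1ccccc1)C(=O)N1CCC[C@H]1c1ncc(-c2ccc(-c3ccc(-c4cnc([C@@H]5CCCN5C(=O)[C@@H](NC(=O)OC)C(C)C)[nH]4)cc3)cc2)[nH]1` carries a benzyl sulfoxide on a saturated chain carbon of its side chain. In an ADME assay on PBMC cells (Homo sapiens) for cytotoxicity (a higher number here means that more compound is tolerated, a lower number that less compound is tolerated), compound 3 gives 42000 nM, the highest of the two numbers shown. Compound 1 `COC(=O)N[C@@H](CSC)C(=O)N1CCC[C@H]1c1ncc(-c2ccc(-c3ccc(-c4cnc([C@@H]5CCCN5C(=O)[C@@H](NC(=O)OC)C(C)C)[nH]4)cc3)cc2)[nH]1`, which carries a methyl thioether at the same place, gives 31000 nM in this assay, and a 1.4-fold higher number from compound 1 to compound 3 (0.13 log units; within the scatter). Compound 2 `COC(=O)N[C@@H](CSCc1ccccc1)C(=O)N1CCC[C@H]1c1ncc(-c2ccc(-c3ccc(-c4cnc([C@@H]5CCCN5C(=O)[C@@H](NC(=O)OC)C(C)C)[nH]4)cc3)cc2)[nH]1` gives in this assay only a limit, > 100000 nM; this is the limit of > 100000 nM in this assay, at which 1 of the 3 values shown sits.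

Compound 4 `COC(=O)N[C@@H](CS(=O)(=O)Cc1ccccc1)C(=O)N1CCC[C@H]1c1ncc(-c2ccc(-c3ccc(-c4cnc([C@@H]5CCCN5C(=O)[C@@H](NC(=O)OC)C(C)C)[nH]4)cc3)cc2)[nH]1` differs from compound 3 in one place: a group of 10 heavy atoms (7 carbon, 2 oxygen, 1 sulfur; one six-membered aromatic ring of carbon only) in place of a group of 9 heavy atoms (7 carbon, 1 oxygen, 1 sulfur; one six-membered aromatic ring of carbon only), on a saturated chain carbon, two bonds along the chain from an amide-type nitrogen and a carbonyl carbon. Among the compounds with values here, the steps that bear on this change are an at least 3.2-fold higher number from compound 1 to compound 2 (0.50 log units; beyond the scatter) and an at least 2.3-fold lower number from compound 2 to compound 3 (0.37 log units; beyond the scatter), both touching the same sulfur-bearing chain, while the oxidation state of that sulfur has so far moved the number by only a modest, limit-bounded amount. A further oxidation is therefore expected to give no step beyond the scatter, and compound 4 is estimated at 45000 nM, between 20000 nM and 100000 nM, meaning an expected step of a 1.1-fold higher number from compound 3 to compound 4 (0.03 log units; within the scatter).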

Compound 4, half-maximal cytotoxic concentration: 21000 nM
Beside the measured number, compound 4's estimate is 2.1-fold (0.33 log units) above it, and the stated range covers the measured number.
By their numbers in this assay, from the lowest: compounds 4, 1 and 3 (each within the scatter of the next). At a limit, above all of these: compound 2.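

In this assay, the benzylsulfonyl group gives a 2.0-fold lower number from compound 3 to compound 4 (0.30 log units; within the scatter) and a 1.5-fold lower number from compound 1 to compound 4 (0.17 log units; within the scatter), so compounds carrying the benzyl sulfoxide, the benzylsulfonyl and the methylsulfanyl groups cannot be told apart in this measurement, and a second oxygen on the sulfur adds no clear change. Only the benzylsulfanyl compound stands apart from the benzylsulfonyl one, with an at least 4.7-fold lower number from compound 2 to compound 4 (0.67 log units; beyond the scatter). The number for compound 2 is a limit and not an exact value: the limit of > 100000 nM in this assay, at which 1 of the 4 values shown sits.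

As far as these compounds go, how wide the gap to compound 2 really is therefore stays open. Also open, from the compounds shown here alone, is what a methylsulfonyl group, an amine or carboxylic acid on the phenyl ring, or a longer chain between the sulfur and that ring would give at this position.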